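Chain Extension in a Quinazoline Ester Series on A549 Cells

A few compounds are considered here, and "the series" means these few. Any claim that something is new, unique, unknown or untested is made for them only; others in the source may bear on it.

Three esters built on one shared core have been tested. Compound 1 `CCCCOC(=O)CCC(=O)N1CCN(CCCOc2cc3c(Nc4ccc(F)c(Cl)c4)ncnc3cc2OC)CC1` gives 86% in a functional assay on A549 cells (Homo sapiens) for cytotoxicity, read by MTT assay, with a stated time of 24 h, tested at 20 uM; a lower number here means a stronger effect, a higher number a weaker effect of the compound at the concentration tested. Compound 2 `CCCCCOC(=O)CCC(=O)N1CCN(CCCOc2cc3c(Nc4ccc(F)c(Cl)c4)ncnc3cc2OC)CC1` gives 81.2% in this assay, and the step of a number 4.8 percentage points lower from compound 1 to compound 2 (within the scatter) corresponds to the change (methyl in place of hydrogen on a saturated chain carbon, four bonds along the chain from an oxygen next to a carbonyl group). Compound 3 `CCCCCCCCCCCCCCCCCCOC(=O)CCC(=O)N1CCN(CCCOc2cc3c(Nc4ccc(F)c(Cl)c4)ncnc3cc2OC)CC1` gives 90.5% in this assay; the difference between the core of compound 3 and that of compound 1 is not broken down here, and its values against compounds 1 and 2 all lie within the scatter.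

Compound 4 `CCCCCCCCCCCCCCCCCCCOC(=O)CCC(=O)N1CCN(CCCOc2cc3c(Nc4ccc(F)c(Cl)c4)ncnc3cc2OC)CC1` is not yet measured. It differs from compound 3 by methyl in place of hydrogen on a saturated chain carbon, ten or more bonds along the chain from an oxygen next to a carbonyl group, the same kind of change as from compound 1 to compound 2, though it sits at a different place along the chain. Because a number 4.8 percentage points lower from compound 1 to compound 2 (within the scatter) stayed within the scatter, compound 4 is expected to change by a number 1.5 percentage points lower from compound 3 to compound 4 (within the scatter), and its value is estimated at 89%, between 79% and 98%.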

Compound 4, a percentage reported as activity, at one concentration (the size of the read-out at that concentration, not a potency): 94.8%
Compound 4: middle estimate off by 5.8 percentage points, on the low side; measured number inside the range.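

In this assay the added methyl on the long chain gives a number 4.3 percentage points higher from compound 3 to compound 4 (within the scatter). Set beside the earlier step, this result does not differ from it: the same change on two cores in this assay, a number 4.8 percentage points lower (within the scatter) from compound 1 to compound 2 and a number 4.3 percentage points higher (within the scatter) from compound 3 to compound 4, 9.1 percentage points apart, within the scatter of two such steps. The two steps show that the change left no effect beyond the scatter on either core, but they do not establish a transferable effect of the methyl group, nor do they show how it would behave on any other core in this series.

All the esters shown carry plain saturated chains. From the compounds shown here alone, a chain ending in an amine or a carboxylic acid, or a phenyl ring in place of the chain, remains open, as does whether either would separate from these esters in this assay.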